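The compounds below may be only part of what the source reports. "The series", "measured", "known", "first", "only" and "open" are said of these compounds alone.

Measured compounds, inhibition data in a functional assay on U-87MG ATCC cells for inhibition, with U-87 MG (Homo sapiens) as the target, read by MTT assay, with a stated time of 48 h; a higher number here means a weaker inhibitor, a lower number a stronger inhibitor:

Compound 1 `COc1cc(/C=N/Nc2nc(-c3cccc(Br)c3)cs2)c(Br)c(Br)c1OC` gives 27600 nM in this assay.
Compound 2 `COc1cc(/C=N/Nc2nc(-c3ccc(F)c(F)c3)cs2)c(Br)c(Br)c1OC` gives 19600 nM in this assay.

Compound 2 stands at the lowest of the two numbers, with compound 1 as its nearest neighbour; the step of a 1.4-fold lower number from compound 1 to compound 2 (0.15 log units; within the scatter) is within the scatter, so the two values do not separate.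

Compound 3 `COc1cc(/C=N/Nc2nc(-c3ccc(Br)cc3)cs2)c(Br)c(Br)c1OC` has not yet been measured in this assay. It differs from compound 2 in one place: 4-bromophenyl in place of 3,4-difluorophenyl on an aromatic carbon. For the measured compounds named here, the only measured step that bears on this position is the one from compound 1 to compound 2, where the group on that aromatic carbon was exchanged once already and the value moved by a 1.4-fold lower number from compound 1 to compound 2 (0.15 log units; within the scatter), within the scatter. Two data points give no trend to extrapolate; the expectation is therefore no step beyond the scatter in this assay, with the value of compound 3 estimated to stay close to that of compound 2, a step of a 1.2-fold higher number from compound 2 to compound 3 (0.09 log units; within the scatter).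

Compound 3 is estimated at 24000 nM, within a range of 9000 nM to 65000 nM.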

Compound 3, half-maximal inhibitory concentration: > 100000 nM
Compound 3 was reported as a limit (the forecaster's own chance of this, stated with the estimate: 10%); at least 4.1-fold (0.61 log units) between middle value and limit.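

In this assay compound 3 gives > 100000 nM, which is a limit of the assay and not a number. The aryl group on this aromatic carbon of the five-membered aromatic ring with 1 nitrogen and 1 sulfur does affect the read-out, which the earlier exchange within the scatter could not show: 4-bromophenyl in place of 3,4-difluorophenyl gives an at least 5.1-fold higher number from compound 2 to compound 3 (0.70 log units; beyond the scatter). Moving the bromine alone, with 4-bromophenyl in place of 3-bromophenyl, also gives a step beyond the scatter, an at least 3.6-fold higher number from compound 1 to compound 3 (0.55 log units; beyond the scatter), so the arrangement on the phenyl counts here and not only which halogen it carries, although the 3,4-difluorophenyl of compound 2 shows that a substituent at the 4 place does not by itself give this loss.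

Going by these compounds, the true size of both steps remains open, as compound 3 has no numerical value: the limit of > 100000 nM in this assay, at which 1 of the 3 values shown sits. Also open, on these data alone, is whether a plain phenyl, a 4-fluorophenyl or a phenyl carrying an amine or a carboxylic acid would read with compound 1 and compound 2 or with compound 3, and whether any group here gives a stronger inhibitor than these two.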